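Fluoro in place of methoxy on compound 3

The source may report more compounds than this note shows. Statements on the series, on what has been measured and on what is new or still open speak of the compounds shown alone.

In an ADME assay on cells (Hepatocyte, Mus musculus) for cytotoxicity, read by MTT assay, with a stated time of 24 h (a higher number here means that more compound is tolerated, a lower number that less compound is tolerated), compound 3 `COc1ccc(S(=O)(=O)n2c(-c3cn(-c4ccccc4)nc3-c3ccc(C(F)(F)F)cc3)nc3ccccc32)cc1` gives 87400 nM. This lies within the scatter of compound 2 `COc1ccc(S(=O)(=O)n2c(-c3cn(-c4ccccc4)nc3-c3ccc(F)cc3)nc3ccccc32)cc1` at 105000 nM and of compound 1 `Cc1ccc(-c2nn(-c3ccccc3)cc2-c2nc3ccccc3n2S(=O)(=O)c2ccc(F)cc2)cc1` at 167000 nM, so the three numbers do not separate. Compound 4 `O=S(=O)(c1ccc(F)cc1)n1c(-c2cn(-c3ccccc3)nc2-c2ccc(C(F)(F)F)cc2)nc2ccccc21` differs from compound 3 in one place, (fluoro in place of methoxy on an aromatic carbon), where (4-methoxyphenyl)sulfonyl becomes (4-fluorophenyl)sulfonyl.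

Among the compounds with values here, no measured step isolates this change. Within the data shown here, the only step available is a 1.2-fold lower number from compound 2 to compound 3 (0.08 log units; within the scatter), trifluoromethyl in place of fluoro at a different place in the molecule, and it stays within the scatter. Compound 1 already carries the (4-fluorophenyl)sulfonyl group and stands at 167000 nM, but it also differs from compound 3 elsewhere, so it offers only a loose guide. Among the measured compounds shown here, the numbers so far therefore give no reason to expect a real shift in this assay, and any drift towards compound 1 would be slight. The expected step is a 1.3-fold higher number from compound 3 to compound 4 (0.12 log units; within the scatter), which would remain inside the scatter. Compound 4 is estimated at 115000 nM, with an expected range of 65000 nM to 190000 nM.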

Compound 4, half-maximal cytotoxic concentration: 83300 nM
The estimate for compound 4 lay 1.4-fold (0.14 log units) above the measured number; low and high end bracket the measured number.
By their numbers in this assay, from the lowest: compounds 4, 3, 2 and 1 (each within the scatter of the next).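

In this assay this position now has a direct reading: a 1.0-fold lower number from compound 3 to compound 4 (0.02 log units; within the scatter) shows that fluoro in place of methoxy, on an aromatic carbon para to a large group, does not separate the two compounds. Within the data shown here, the second step, a 2.0-fold lower number from compound 1 to compound 4 (0.30 log units; within the scatter), gives a first reading of a change from methyl to trifluoromethyl, and this change does not separate its pair either. Both changes therefore leave the number within the scatter, and no accompanying measurement offers an explanation for these results.

The compounds shown leave open whether an amine or a carboxylic acid at this position would separate from methoxy and fluoro. They also leave open whether a longer chain in place of methoxy would give a step beyond the scatter.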